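Swapping the aryl group on the saturated ring carbon

The compounds below may be only part of what the source reports. "The series", "measured", "known", "first", "only" and "open" are said of these compounds alone.

Compound 1 `CCCc1ccc(C2CC(c3ccc(O)cc3)=NN2C(=O)c2cccnc2)cc1`: 41600 nM
Compound 2 `COc1ccc(OC)c(C2CC(c3ccc(O)cc3)=NN2C(=O)c2cccnc2)c1`: 56800 nM
Compound 3 `O=C(c1cccnc1)N1N=C(c2ccc(O)cc2)CC1c1ccc(F)cc1`: 52400 nM

These three compounds were tested in an ADME assay on HepG2 cells (Homo sapiens) for cytotoxicity, read by MTT assay, with a stated time of 7 days; a higher number here means a weaker inhibitor, a lower number a stronger inhibitor. Compound 1 sits at the low end of the three numbers, yet the steps of a 1.4-fold higher number from compound 1 to compound 2 (0.14 log units; within the scatter) and a 1.3-fold higher number from compound 1 to compound 3 (0.10 log units; within the scatter) both stay within the scatter, so the three are indistinguishable here. Compound 4 `O=C(c1cccnc1)N1N=C(c2ccc(O)cc2)CC1c1ccccc1Cl` differs from compound 1 in one place: 2-chlorophenyl in place of 4-propylphenyl on a saturated ring carbon. The aryl swaps already seen on this saturated ring carbon, a 1.4-fold higher number from compound 1 to compound 2 (0.14 log units; within the scatter) and a 1.1-fold lower number from compound 2 to compound 3 (0.04 log units; within the scatter), moved nothing beyond the scatter. A similar outcome is therefore expected for compound 4, namely a 1.2-fold higher number from compound 1 to compound 4 (0.08 log units; within the scatter). The estimate for compound 4 is 50000 nM, with a range of 25000 nM to 100000 nM.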

Compound 4, half-maximal inhibitory concentration: 47700 nM
For compound 4 the middle estimate is 1.0-fold (0.02 log units) above the measured one; the range from low to high includes it.
By their numbers in this assay, from the lowest: compounds 1, 4, 3 and 2 (each within the scatter of the next).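

With 2-chlorophenyl on this saturated ring carbon, this assay still separates nothing: it stays within the scatter against 4-propylphenyl (a 1.1-fold higher number from compound 1 to compound 4 (0.06 log units; within the scatter)), against 4-fluorophenyl (a 1.1-fold lower number from compound 3 to compound 4 (0.04 log units; within the scatter)) and against 2,5-dimethoxyphenyl (a 1.2-fold lower number from compound 2 to compound 4 (0.08 log units; within the scatter)). All four aryl groups shown, including this first chlorine-bearing one, therefore give indistinguishable numbers at this position. No available evidence accounts for this flat result. Still open, on these data alone, is whether an aryl group carrying an amine or a carboxylic acid would shift the number here.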